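Cyclopropylamino in place of 2-aminobutoxy on the shared core

A few compounds are considered here, and "the series" means these few. Any claim that something is new, unique, unknown or untested is made for them only; others in the source may bear on it.

Measured compounds:
compound 1, `CC[C@H](CO)Nc1nc(NC(=N)N)c2ncn(C(C)C)c2n1`, 4500 nM
compound 2, `CC[C@H](N)COc1nc(NC(=N)N)c2ncn(C(C)C)c2n1`, 16300 nM

Both numbers come from a functional assay on MCF7 cells (Homo sapiens) for inhibition, read by fluorescence, with a stated time of 72 h; a lower number here means a stronger inhibitor, a higher number a weaker inhibitor. Among the compounds with values here, compound 2 gives the higher of the two; its only neighbour is compound 1, and the one measured step in the set, a 3.6-fold higher number from compound 1 to compound 2 (0.56 log units; beyond the scatter), separates them. Within the data shown here, that step is the sole precedent for a change on an aromatic carbon of the shared core, and it takes a nitrogen-joined group in compound 1 to an oxygen-joined group in compound 2.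

Compound 3, `CC(C)n1cnc2c(NC(=N)N)nc(NC3CC3)nc21`, is not yet measured in this assay. It differs from compound 2 by cyclopropylamino in place of 2-aminobutoxy on an aromatic carbon. The group that enters is again joined through nitrogen, as in compound 1, while the 2-aminobutoxy of compound 2 leaves. The step from compound 1 to compound 2 is therefore the relevant comparison, read in reverse; it was modest but beyond the scatter. A return roughly to the level of compound 1 is expected, so compound 3 is estimated at 5000 nM (range 1500 nM to 16000 nM). This is expected to correspond to a step of a 3.3-fold lower number from compound 2 to compound 3 (0.51 log units; beyond the scatter).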

Compound 3, half-maximal inhibitory concentration: 5400 nM
Beside the measured number, compound 3's estimate is 1.1-fold (0.03 log units) below it; measured number inside the range.
By their numbers in this assay, from the lowest: compounds 1 and 3 (each within the scatter of the next); then compound 2.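

In this assay, the aromatic carbon between two ring nitrogen atoms now has a second nitrogen-joined group, and cyclopropylamino in place of 2-aminobutoxy gives a 3.0-fold lower number from compound 2 to compound 3 (0.48 log units; beyond the scatter) as a modest step, opposite in direction to a 3.6-fold higher number from compound 1 to compound 2 (0.56 log units; beyond the scatter) on the same carbon. The group carried on that nitrogen can differ widely here: cyclopropyl in place of 1-(hydroxymethyl)propyl gives a 1.2-fold higher number from compound 1 to compound 3 (0.08 log units; within the scatter) and stays within the scatter, so the three-membered ring and the open chain with its hydroxyl cannot be told apart in this assay. Among these three compounds, both nitrogen-joined groups give lower numbers than the oxygen-joined group of compound 2, but that is a single oxygen-joined case, and there is no evidence to explain either step.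

The step to compound 3 changes the joining atom and the whole side chain together, so the share of the oxygen link alone stays unresolved. Also open, as far as these compounds go, is whether a simple oxygen-joined group such as methoxy, a plain amine or a longer chain such as n-hexylamino on this carbon would fall with the nitrogen-joined pair or with compound 2.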